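Halogen swap on benzohydroxamic acids: cytotoxicity outlook

A few compounds are considered here, and "the series" means these few. Any claim that something is new, unique, unknown or untested is made for them only; others in the source may bear on it.

Compound 1 `O=C(NO)c1ccccc1Cl`: 330000 nM
Compound 2 `O=C(NO)c1ccccc1Br`: 270000 nM
Compound 3 `O=C(NO)c1ccc(Cl)cc1`: 55000 nM

All three were tested in an ADME assay on Huh-7 cells (Homo sapiens) for cytotoxicity, read by MTT assay, with a stated time of 72 h; on this read-out higher numbers stand for lower toxicity in this test and lower numbers for higher toxicity in this test. In this assay compound 1 gives 330000 nM. Compound 2 gives 270000 nM. Compound 3 gives 55000 nM, the lowest of the three, so it is the most toxic in this test, with compound 2 the nearest and compound 1 the furthest of the other two.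

Compound 1 and compound 2 differ by bromo in place of chloro on an aromatic carbon. That change gave a 1.2-fold lower number from compound 1 to compound 2 (0.09 log units; within the scatter).

Compound 4 `O=C(NO)c1ccc(Br)cc1` has not been measured. It differs from compound 3 by bromo in place of chloro on an aromatic carbon. This is the same kind of change as from compound 1 to compound 2, but not the same: there the bromo sits ortho to a group of 4 heavy atoms, here para to it. The difference between the two cores of compound 1 and compound 3 is not broken down here.

Because a 1.2-fold lower number from compound 1 to compound 2 (0.09 log units; within the scatter) stayed within the scatter, compound 4 is expected to sit close to compound 3, with an expected step of a 1.1-fold lower number from compound 3 to compound 4 (0.04 log units; within the scatter). The estimate for compound 4 in this assay is 50000 nM, expected to fall between 25000 nM and 110000 nM.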

Compound 4, half-maximal cytotoxic concentration: 25000 nM
For compound 4 the middle estimate is 2.0-fold (0.30 log units) above the measured one, within the range that was stated.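

In this assay, bromo in place of chloro on the core of compound 3 gave a 2.2-fold lower number from compound 3 to compound 4 (0.34 log units; beyond the scatter), a modest move towards higher toxicity in this test. Set beside the earlier swap, this step does not differ from it by more than two such steps would usually scatter: the same change on two cores in this assay, a 1.2-fold lower number (0.09 log units; within the scatter) from compound 1 to compound 2 and a 2.2-fold lower number (0.34 log units; beyond the scatter) from compound 3 to compound 4, 1.8-fold (0.26 log units) apart, within the scatter of two such steps. So the swap can be carried between these two cores with a similar expected effect, but this rests on only two pairs and does not show that the place of the halogen on the ring sets the size of the step, or that the same would hold on any other core.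

The compounds shown carry only chloro and bromo, which leaves open how fluoro, iodo, a methoxy group, an amine or a carboxylic acid in the same place would compare. Going by these compounds, it also remains open whether the swap would give a similar step on a core that carries a longer chain.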